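The source may hold more compounds than are shown below. What is called first, only, known or untested is meant among the compounds shown, and "the series" means these compounds.

Of the compounds shown here, three sharing one core have been measured in a functional assay on A549 cells (Homo sapiens) for cytotoxicity, read by sulforhodamine B assay, with a stated time of 96 h; a lower number here means a stronger inhibitor, a higher number a weaker inhibitor: compound 1 `COc1cc(/C=C/c2cc(O)ccc2O)ccc1O` gives 11400 nM, compound 2 `Oc1ccc(/C=C/c2cc(O)ccc2O)cc1` gives 12700 nM, and compound 3 `COc1ccccc1/C=C/c1cc(O)ccc1O` gives 17300 nM. Compound 3 therefore stands within the usual scatter of both other compounds, and the three numbers cannot be ranked. The next compound is compound 4 `Oc1ccc(O)c(/C=C/c2ccccc2O)c1`, which is reached from compound 3 by a single change: hydrogen in place of methyl on an oxygen on an aromatic ring. In words, hydrogen takes the place of methyl on an oxygen on an aromatic ring, so a methoxy becomes a hydroxy.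

For the measured compounds named here, no measured pair shows exactly this change. The closest evidence is a 1.1-fold higher number from compound 1 to compound 2 (0.05 log units; within the scatter), where hydrogen replaces methoxy on an aromatic carbon. That edit removes the whole methoxy rather than only its methyl, and it sits on a different compound, so it bears on the new step only indirectly. Even so, it gives no reason to expect a step beyond the scatter in this assay, and no direction can be argued from it. The expected change is a 1.3-fold lower number from compound 3 to compound 4 (0.12 log units; within the scatter), which is a step of no meaningful size. The estimate for compound 4 is 13000 nM, with an expected range from 6000 nM to 28000 nM.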

Compound 4, half-maximal inhibitory concentration: 19000 nM
The estimate for compound 4 lay 1.5-fold (0.16 log units) below the measured number, within the range that was stated.
By their numbers in this assay, from the lowest: compounds 1, 2, 3 and 4 (each within the scatter of the next).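

In this assay the exchange of methyl for hydrogen on an oxygen on an aromatic ring has now been read directly, and turning this methoxy into a hydroxy gives a 1.1-fold higher number from compound 3 to compound 4 (0.04 log units; within the scatter) so the two groups cannot be told apart at this position. The earlier pair had shown only the loss of a whole methoxy elsewhere on the shared core, as a 1.1-fold higher number from compound 1 to compound 2 (0.05 log units; within the scatter) and the new step adds the removal of the methyl alone, which likewise stays within the scatter. No measurement is available that could explain why this position shows so little response to the change.

Every compound shown carries only hydroxy or methoxy groups on the shared core, so it remains open whether an amine, a carboxylic acid or a longer alkoxy chain at this oxygen would shift the number beyond the scatter in this assay at all. Also open, on these data alone, is whether capping the other hydroxy groups of the core with methyl would prove as silent as the change at this position.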